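Benzylamine variation on a diaminoquinoxaline-type growth inhibitor

A few compounds are considered here, and "the series" means these few. Any claim that something is new, unique, unknown or untested is made for them only; others in the source may bear on it.

Measured compounds:
compound 1, `Nc1cc(N)c2nc(-c3ccccc3)c(NCc3ccc(Cl)c(Cl)c3)nc2c1`, 1660 nM
compound 2, `CCOC(=O)[C@H](CCC(=O)O)NC(=O)c1ccc(Sc2nc3cc(N)cc(N)c3nc2-c2ccccc2)cc1`, 339 nM

In a functional assay on RPMI8266 cells (Homo sapiens) for inhibition, read by sulforhodamine B assay, with a stated time of 48 h (on this read-out higher numbers stand for weaker inhibition of growth and lower numbers for stronger inhibition of growth), compound 1 gives 1660 nM, the highest of the two numbers; compound 2 gives 339 nM, a lower number, and the gap between them lies beyond the scatter. Compound 3, `COc1ccc(CNc2nc3cc(N)cc(N)c3nc2-c2ccccc2)cc1`, has not been measured. It differs from compound 1 by 4-methoxyphenyl in place of 3,4-dichlorophenyl on a saturated chain carbon bound to a nitrogen on an aromatic ring. Within the data shown here, no measured pair shows this change, so its effect is unknown; the account expects at most a modest shift toward a higher number, possibly none beyond the scatter, as a 1.7-fold higher number from compound 1 to compound 3 (0.23 log units; within the scatter). Compound 3 is therefore estimated at 2800 nM, with a range from 800 nM to 10000 nM.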

Compound 3, concentration for 50% growth inhibition: 4170 nM
For compound 3 the middle estimate is 1.5-fold (0.17 log units) below the measured one; the range from low to high includes it.
By their numbers in this assay, from the lowest: compound 2; then compound 1; then compound 3.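

On the saturated chain carbon bound to a nitrogen on an aromatic ring, the aryl group matters: in this assay, 4-methoxyphenyl in place of 3,4-dichlorophenyl gives a 2.5-fold higher number from compound 1 to compound 3 (0.40 log units; beyond the scatter), a modest step. Both groups count the same heavy atoms, yet the entering group holds one hydrogen-bond acceptor and the leaving group none. Nothing at hand explains the step.

From the compounds shown here alone, because the chlorines leave and the methoxy enters in one change, their separate shares stay open. Where an unsubstituted phenyl, a 4-chlorophenyl or a ring bearing a carboxylic acid would fall is also unknown.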